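This account rests on a few compounds, and the source may have more. Where it says the series, first, only, none or still open, it means among the compounds named here.

Among the compounds with values here, compound 2 `CC(O)(C(=O)Nc1ccc(S(=O)(=O)c2cccc(O)c2)cc1)C(F)(F)F` gives 18000 nM in a functional assay (Cavia porcellus) with sulfonylurea receptors; K-ATP channels (Homo sapiens) as the target (a lower number here means a stronger inhibitor, a higher number a weaker inhibitor), the higher of the two numbers measured so far, and the only other measured compound is compound 1 `CC(O)(C(=O)Nc1ccc(S(=O)(=O)c2ccccc2C#N)cc1)C(F)(F)F`, which in this assay gives 1100 nM. Within the data shown here, the one measured step shows a 16-fold higher number from compound 1 to compound 2 (1.21 log units; beyond the scatter). Compound 3 `CC(O)(C(=O)Nc1ccc(S(=O)(=O)c2ccccc2Cl)cc1)C(F)(F)F` has not yet been measured in this assay. The change from compound 2 to compound 3 is 2-chlorophenyl in place of 3-hydroxyphenyl on a sulfonyl sulfur. Among the measured compounds shown here, this move is not the reverse of the measured step, since compound 3 carries a 2-chlorophenyl rather than the 2-cyanophenyl of compound 1, but both of those groups sit on the sulfonyl sulfur in place of the 3-hydroxyphenyl of compound 2, and the measured step of a 16-fold higher number from compound 1 to compound 2 (1.21 log units; beyond the scatter) is the only guide. Compound 3 is therefore expected to move back toward compound 1, giving a large step downward, a 12-fold lower number from compound 2 to compound 3 (1.08 log units; beyond the scatter), in this assay. For the measured compounds named here, for compound 3 the estimate in this assay is 1500 nM, with a range from 500 nM to 6000 nM, the width reflecting that only one measured step informs this expectation.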

Compound 3, half-maximal inhibitory concentration: 2300 nM
Compound 3: the middle estimate sits 1.5-fold (0.19 log units) below what was measured; the measured number falls inside the stated range.
By their numbers in this assay, from the lowest: compound 1; then compound 3; then compound 2.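

In this assay, 2-chlorophenyl in place of 3-hydroxyphenyl on the sulfonyl sulfur gives a 7.8-fold lower number from compound 2 to compound 3 (0.89 log units; beyond the scatter), so the lower number seen with 2-cyanophenyl is not confined to that one group: two different groups at this place now give lower numbers than 3-hydroxyphenyl. The two are not interchangeable, since chloro in place of cyano on an aromatic carbon gives a 2.1-fold higher number from compound 1 to compound 3 (0.32 log units; beyond the scatter), a modest step that leaves compound 3 between compound 1 and compound 2 in the order of the three numbers. No measurement available here accounts for either step.

The compounds shown leave open whether the high number of compound 2 goes with the hydroxyl group itself or with where it stands on the ring, since the group and its place change together in both steps from compound 2. A 2-hydroxyphenyl or a 3-chlorophenyl group would separate those two changes, and a 2-aminophenyl group would show how far this place extends beyond the chloro and nitrile groups.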